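The source may report more compounds than this note shows. Statements on the series, on what has been measured and on what is new or still open speak of the compounds shown alone.

Measured so far in an assay on isolated protein for inhibition of advanced glycosylation end product-specific receptor (Homo sapiens), read by FRET, with stated times of 30 min and 1 h, tested at 4 uM; on this read-out higher numbers stand for more inhibition at the one concentration tested (going by the name of the read-out) and lower numbers for less inhibition:
- compound 1, `Clc1ccc(Oc2ccc3nc(-c4ccc(OCCCN5CCCCC5)cc4)oc3c2)cc1`, gives 2.2%
- compound 2, `CCN(CC)CCCOc1ccc(-c2nc3ccc(Oc4ccc(F)cc4)cc3o2)cc1`, gives 5.4%

Compound 2 holds the higher of the two numbers in this assay, but its nearest neighbour, compound 1, sits only a little lower, and that gap falls inside the usual scatter of repeated runs; the two are not separable on these data. Both readings are low, so neither compound shows much inhibition at the single concentration tested.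

The next compound, compound 3, `Fc1ccc(Oc2ccc3nc(-c4ccc(OCCCN5CCCCC5)cc4)oc3c2)cc1`, is compound 2 with one change: piperidin-1-yl in place of diethylamino on a saturated chain carbon, three bonds along the chain from an oxygen on an aromatic ring. Going by the values given here, no step between two measured compounds has been worked out, so there is no measured anchor for what this swap does. Compound 1 already carries the piperidin-1-yl group and reads low, which gives no reason to expect a large move. The step from compound 2 to compound 3 in this assay is expected to be small, a number 1.4 percentage points lower from compound 2 to compound 3 (within the scatter), in no direction beyond the scatter. Compound 3 is estimated at 4%, with a range from -5% to 13%.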

Compound 3, a percentage reported as inhibition, at one concentration (the size of the read-out at that concentration, not a potency): 30.3%
The estimate for compound 3 lay 26.3 percentage points below the measured number; measured number outside the range, above it.
By their numbers in this assay, from the lowest: compounds 1 and 2 (each within the scatter of the next); then compound 3.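

a number 24.9 percentage points higher from compound 2 to compound 3 (beyond the scatter) is the first step in this assay to lie beyond the scatter, and it comes from piperidin-1-yl replacing diethylamino at the end of the propyl chain while fluoro stays in place. With 3-(piperidin-1-yl)propyl held constant, fluoro in place of chloro on an aromatic carbon gives a number 28.1 percentage points higher from compound 1 to compound 3 (beyond the scatter) in the same assay, so the reading responds to a change at either place. Among these compounds, only compound 3 carries fluoro together with piperidin-1-yl, and nothing measured here accounts for either step.

Still open, on these data alone, is how chloro behaves with 3-(diethylamino)propyl, and thus whether the two changes depend on each other. Also open, as far as these compounds go, are the effects of a morpholine or pyrrolidine at the chain end, a shorter or longer chain, and a methoxy group or bromo in place of the halogen.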